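From 4-Chlorophenyl to 2-Chlorophenyl on the Carbonyl

The source may hold more compounds than are shown below. What is called first, only, known or untested is meant among the compounds shown, and "the series" means these compounds.

Compound 2 `O=C(c1ccncc1)N(/N=C/c1c[nH]nc1-c1cccc(Cl)c1)C(=O)c1ccc(Cl)cc1` is the starting point. In an ADME assay on Vero cells (Chlorocebus sabaeus) for inhibition, read by MTT assay, with a stated time of 3 days (a higher number here means a weaker inhibitor, a lower number a stronger inhibitor), compound 2 gives > 1000 ug/mL, which is a limit of the assay rather than a number. Compound 1 `O=C(N/N=C/c1c[nH]nc1-c1cccc(Cl)c1)c1ccncc1` lacks the (4-chlorophenyl)carbonyl. In this assay compound 1 gives > 1000 ug/mL, also a limit. The step that the two limits leave unreadable from compound 1 to compound 2 cannot be sized, since both values sit at the limit (the limit of > 1000 ug/mL in this assay, at which 2 of the 2 values shown sit). Compound 3 `O=C(c1ccncc1)N(/N=C/c1c[nH]nc1-c1cccc(Cl)c1)C(=O)c1ccccc1Cl` differs from compound 2 by 2-chlorophenyl in place of 4-chlorophenyl on a carbonyl carbon. No measured step sizes this change, so compound 3 is expected to remain at the limit, with an estimated 1000 ug/mL spanning 500 ug/mL to 2000 ug/mL, and an expected step of a number no higher from compound 2 to compound 3 (the limit leaves the size open) of none beyond the scatter.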

Compound 3, half-maximal inhibitory concentration: 513 ug/mL
Compound 3: middle estimate off by 1.9-fold (0.29 log units), on the high side; low and high end bracket the measured number.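

In this assay compound 3 gives 513 ug/mL, a number rather than a limit, so a change in the group on this carbonyl carbon can register in this read-out: the limit of > 1000 ug/mL in this assay, at which 2 of the 3 values shown sit.

Putting 2-chlorophenyl in place of 4-chlorophenyl gives an at least 1.9-fold lower number from compound 2 to compound 3 (0.28 log units; that floor lies within the scatter), and putting (2-chlorophenyl)carbonyl in place of hydrogen on the amide-type nitrogen gives an at least 1.9-fold lower number from compound 1 to compound 3 (0.28 log units; that floor lies within the scatter). Both are only floors, and the step from compound 1 to compound 2 cannot be read.

As far as these compounds go, how far the true steps exceed these floors remains open. So does what a phenyl carrying an amine or a carboxylic acid in place of chlorine would give.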